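The source may hold more compounds than are shown below. What is called first, only, known or untested is meant among the compounds shown, and "the series" means these compounds.

Of the compounds shown here, three sharing one core have been tested in an assay on isolated protein with malate dehydrogenase, mitochondrial (Sus scrofa) as the target; a higher number here means a weaker inhibitor, a lower number a stronger inhibitor. Compound 2 `O=C(O)c1cnc2cc(OCCOc3ccccc3)ccc2c1O` gives 60300 nM, the second highest of the three numbers. Compound 1 `O=C(O)c1cnc2cc(OCc3c(Cl)c(Cl)c(Cl)c(Cl)c3Cl)ccc2c1O`, nearest to it, gives 4790 nM, a lower and so stronger result, a gap beyond the scatter. Compound 3 `O=C(O)c1cnc2cc(S(=O)(=O)O)ccc2c1O`, furthest from it, gives 2140000 nM, a weaker result, also beyond the scatter. Compound 4 `O=C(O)c1cnc2cc(OCCc3ccc(Br)cc3)ccc2c1O` has not yet been measured in this assay. It differs from compound 2 in one place: 4-bromophenyl in place of phenoxy on a saturated chain carbon, two bonds along the chain from an oxygen on an aromatic ring. Within the data shown here, no measured step of this exact kind exists, so only an expectation can be given: a moderate gain in strength, a step of about a 2.4-fold lower number from compound 2 to compound 4 (0.38 log units; beyond the scatter). Compound 4 is therefore estimated at 25000 nM, within a range from 8000 nM to 80000 nM.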

Compound 4, half-maximal inhibitory concentration: 2510 nM
Beside the measured number, compound 4's estimate is 10-fold (1.00 log units) above it, and the stated range ends above it.
By their numbers in this assay, from the lowest: compounds 4 and 1 (each within the scatter of the next); then compound 2; then compound 3.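

In this assay, putting 4-bromophenyl in place of phenoxy on this saturated chain carbon gives a 24-fold lower number from compound 2 to compound 4 (1.38 log units; beyond the scatter), so this position responds strongly to what is attached there. The change removes the oxygen, along with its hydrogen-bond acceptor, and adds a bromine in one move, so the step cannot be divided between the two. Nothing shown here accounts for the size of this step.

A plain phenyl group at this place, carrying neither the oxygen nor the bromine, would help separate the two. Going by these compounds, whether a 4-chlorophenyl group or a longer chain would do as well also remains open.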